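This account rests on a few compounds, and the source may have more. Where it says the series, first, only, none or still open, it means among the compounds named here.

Compound 1 `COc1ccc(-n2ncnc2-c2cc(OC)c(OC)c(OC)c2)cc1` gives 7400 nM in a functional assay on MCF7 cells (Homo sapiens) for antiproliferative activity, read by MTT assay, with a stated time of 72 h; on this read-out lower numbers stand for stronger inhibition and higher numbers for weaker inhibition. Compound 2 `COc1cc(-c2ncnn2-c2ccc(F)cc2)cc(OC)c1OC` returns only a limit of the assay in this assay, > 10000 nM. Compound 3 `COc1cc(-c2ncnn2-c2ccc([N+](=O)[O-])cc2)cc(OC)c1OC` likewise stops at a limit in this assay, > 10000 nM, so compound 3 stands among the weakest entries shown, with the limit of > 10000 nM in this assay, at which 2 of the 3 values shown sit.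

Of the measured steps, two touch this position: an at least 1.3-fold higher number from compound 1 to compound 3 (0.13 log units; that floor lies within the scatter), and a step that the two limits leave unreadable from compound 2 to compound 3. Neither yields a readable size, and both end at the limit.

Compound 4 `COc1cc(-c2ncnn2-c2ccc(Cl)cc2)cc(OC)c1OC` differs from compound 3 by chloro in place of nitro on an aromatic carbon. Since the fluoro analog compound 2 and the nitro analog compound 3 both sit at the limit, and only the methoxy analog compound 1 gives a number, no step beyond the scatter is expected for the chloro analog, and a further limit is the most likely outcome. Compound 4 is therefore expected to give 12000 nM, in the range 5000 nM to 30000 nM. The step expected is a step that the limit leaves unreadable from compound 3 to compound 4, probably again masked by the limit.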

Compound 4, half-maximal inhibitory concentration: > 10000 nM
Compound 4: a limit, no number; the forecaster's own chance of this, stated with the estimate: 65%; the middle value does not contradict the limit.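

Chloro now joins fluoro and nitro at this position, and compound 4 also stops at a limit of the assay, not a number, in this assay: the limit of > 10000 nM in this assay, at which 3 of the 4 values shown sit. Replacing nitro with chloro, which has fewer heavy atoms and no hydrogen-bond acceptors, still gives no number, and the steps among compound 2, compound 3 and compound 4 cannot be read, so these three groups cannot be ranked. Chloro in place of methoxy gives an at least 1.3-fold higher number from compound 1 to compound 4 (0.13 log units; that floor lies within the scatter), so this floor alone does not establish a real loss.

As far as these compounds go, whether an amine or an ethoxy group at this position would return a number, as compound 1 does with 7400 nM, stays open. From the compounds shown here alone, how far compound 2, compound 3 and compound 4 each lie past the limit also stays open, leaving the true size of each methoxy step unknown.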